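Shifting methyls on the anilide ring of compound 1

The compounds below may be only part of what the source reports. "The series", "measured", "known", "first", "only" and "open" are said of these compounds alone.

Compound 1 `Cc1ccc(NC(=O)/C=C/C(=O)N2C/C(=C\c3ccccc3)C(=O)/C(=C/c3ccccc3)C2)cc1` is tested in a functional assay on Molt4/C8 cells (Homo sapiens) for cytotoxicity (a higher number here means a weaker inhibitor, a lower number a stronger inhibitor), where compound 1 gives 660 nM. Two close relatives share its core but carry nitro groups on the outer rings and a different anilide. Compound 2 `O=C(/C=C/C(=O)N1C/C(=C\c2ccc([N+](=O)[O-])cc2)C(=O)/C(=C/c2ccc([N+](=O)[O-])cc2)C1)Nc1ccc(Cl)c(Cl)c1` gives 600 nM, and compound 3 `O=C(/C=C/C(=O)N1C/C(=C\c2ccc([N+](=O)[O-])cc2)C(=O)/C(=C/c2ccc([N+](=O)[O-])cc2)C1)Nc1ccc(Cl)cc1` gives 1200 nM. Compound 1 lies within the usual scatter of both of them, so none of the three can be set apart on these numbers. Within the data shown here, the only one-point step among them, a 2.0-fold higher number from compound 2 to compound 3 (0.30 log units; within the scatter), is a change on the anilide ring that stayed within the scatter.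

Compound 4 `Cc1cccc(C)c1NC(=O)/C=C/C(=O)N1C/C(=C\c2ccccc2)C(=O)/C(=C/c2ccccc2)C1` differs from compound 1 only on that same anilide nitrogen: 2,6-dimethylphenyl in place of 4-methylphenyl on an amide-type nitrogen. Among the measured compounds shown here, the single step that touches this part of the molecule, from compound 2 to compound 3, stayed within the scatter, and no measured step tells how moving methyls around the anilide ring shifts this assay. The expectation for compound 4 is therefore a step of a 1.1-fold higher number from compound 1 to compound 4 (0.03 log units; within the scatter), with nothing expected beyond the scatter. Compound 4 is estimated at 700 nM, within a range of 300 nM to 1600 nM.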

Compound 4, half-maximal inhibitory concentration: 6600 nM
Beside the measured number, compound 4's estimate is 9.4-fold (0.97 log units) below it, outside the stated range (above it).
By their numbers in this assay, from the lowest: compounds 2, 1 and 3 (each within the scatter of the next); then compound 4.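

In this assay, among these compounds, the anilide ring proves sensitive to change: with the shared core held fixed, 2,6-dimethylphenyl in place of 4-methylphenyl on the amide-type nitrogen gives a 10-fold higher number from compound 1 to compound 4 (1.00 log units; beyond the scatter) and is the first step here to lie beyond the scatter. Among the compounds shown here, the earlier step on this ring, the chloro change between compound 2 and compound 3, stayed within the scatter and gave no sign that this part of the molecule could move the number so far. Nothing available explains why this swap weakens compound 4.

From the compounds shown here alone, one step changes both the number and the places of the methyls, so it remains open which of the two matters. Going by these compounds, it is also open how an amine, a carboxylic acid or a methoxy group on this ring would read, and whether the same swap would weaken the nitro-bearing compounds.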